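The source may hold more compounds than are shown below. What is called first, only, known or untested is meant among the compounds shown, and "the series" means these compounds.

Compound 2, `CCC(=O)N[C@@H]1CCCc2c1cncc2N1Cc2cc(Cl)ccc2C1=O`, is one of three compounds already measured in an ADME assay on microsomes from liver (Mus musculus) for metabolic stability, read by LC-MS, using NADPH, with stated times of 10 min and 30 min; on this read-out higher numbers stand for fast clearance and lower numbers for slow clearance. In this assay compound 2 gives < 20.2 mL/min/kg, which is a limit of the assay rather than a number. Compound 1, `CC[C@H]1c2cc(Cl)ccc2C(=O)N1c1cncc2c1CCC[C@H]2NC(C)=O`, in this assay also gives < 20.2 mL/min/kg, again a limit of the assay. Compound 3, `CCC(=O)N[C@@H]1CCCc2c1cncc2N1C(=O)c2ccc(Cl)cc2[C@H]1C`, in this assay gives 45.6 mL/min/kg. Going by the values given here, the one measured step between close neighbours is an at least 2.2-fold higher number from compound 2 to compound 3 (0.35 log units; beyond the scatter), and its true size is open because it rests on (the limit of < 20.2 mL/min/kg in this assay, at which 2 of the 3 values shown sit).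

Compound 4, `CC(=O)N[C@@H]1CCCc2c1cncc2N1Cc2cc(Cl)ccc2C1=O`, differs from compound 2 by hydrogen in place of methyl on a saturated chain carbon bound to a carbonyl carbon. Among the compounds with values here, no measured step changes this part of the molecule; the only step on record alters a methyl on a saturated ring carbon, which is a different place, so it offers no direct guide. Shortening propanoyl to acetyl is a small change, and in this assay the expected step is a step that the limit leaves unreadable from compound 2 to compound 4, no larger than the usual scatter. For compound 4 the estimate in this assay is 15 mL/min/kg, with a range from 7 mL/min/kg to 30 mL/min/kg.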

Compound 4, clearance: < 20.2 mL/min/kg
Compound 4: only a limit was reported (the forecaster's own chance of this, stated with the estimate: 65%); the middle value is on the limit's open side.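

In this assay compound 4 gives < 20.2 mL/min/kg, which is a limit of the assay. The steps from compound 2 and from compound 1 to compound 4 therefore cannot be read: the limit of < 20.2 mL/min/kg in this assay, at which 3 of the 4 values shown sit.

The compounds shown leave open whether shortening propanoyl to acetyl changes clearance at all, since compound 2 and compound 4 carry only limits.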